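The source may hold more compounds than are shown below. What is called first, only, known or untested is meant among the compounds shown, and "the series" means these compounds.

Measured so far:
Compound 1 `Cn1c(-c2ccccc2)nc2c(NC3CCCC3)ncnc21`: 14 nM in a functional assay on CHO cells for antagonist activity at adenosine receptor A1 (Homo sapiens), read by cAMP accumulation, with a stated time of 10 min; on this read-out higher numbers stand for weaker inhibition and lower numbers for stronger inhibition
Compound 2 `CCCC1CCC(CCC)(n2c(=O)[nH]c3nc[nH]c3c2=O)C1`: 2.9 nM in this assay
Compound 3 `Cn1c(-c2ccc(O)cc2)nc2c(NC3CCCC3)ncnc21`: 52 nM in this assay

Compound 3 stands with the highest number of the three in this assay; compound 1 lies nearest to it and compound 2 furthest. Compound 4 `Cc1cccc(-c2nc3c(NC4CCCC4)ncnc3n2C)c1` differs from compound 3 by 3-methylphenyl in place of 4-hydroxyphenyl on an aromatic carbon. Among the measured compounds shown here, only one measured step bears on this: a 3.7-fold higher number from compound 1 to compound 3 (0.57 log units; beyond the scatter), which introduced the hydroxy that compound 4 now loses again. The added methyl has no measured counterpart among these compounds, so the expectation rests on the hydroxy alone. One therefore expects the number to fall back toward that of compound 1, a step of a 3.5-fold lower number from compound 3 to compound 4 (0.54 log units; beyond the scatter). Compound 4 is estimated at 15 nM, in the range 5 nM to 45 nM.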

Compound 4, half-maximal inhibitory concentration: 43 nM
Compound 4: the middle estimate sits 2.9-fold (0.46 log units) below what was measured, and the stated range covers the measured number.
By their numbers in this assay, from the lowest: compound 2; then compound 1; then compounds 4 and 3 (each within the scatter of the next).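

Exchanging 4-hydroxyphenyl for 3-methylphenyl on this aromatic carbon gives a 1.2-fold lower number from compound 3 to compound 4 (0.08 log units; within the scatter), so losing the hydroxy does not by itself bring the number back toward that of compound 1. The plain phenyl of compound 1 instead stands apart from both substituted rings, with methyl in place of hydrogen giving a 3.1-fold higher number from compound 1 to compound 4 (0.49 log units; beyond the scatter). Nothing available here explains this.

Compound 3 and compound 4 differ in both the group and its place on the ring, so the two remain unseparated. As far as these compounds go, how a methoxy, an amine or a chlorine on this phenyl would read also stays open.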